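A Longer Side Chain on a Compound at the Limit

The source may report more compounds than this note shows. Statements on the series, on what has been measured and on what is new or still open speak of the compounds shown alone.

Of the compounds shown here, three sharing one core have been tested in a functional assay on COLO 205 cells (Homo sapiens) for cytotoxicity, read by MTT assay, with a stated time of 24 h; a lower number here means a stronger inhibitor, a higher number a weaker inhibitor. Compound 1 `CCCCCCCCCCn1cc(-c2nc3ccccc3cc2C)nn1` carries a methyl on that core and a decyl chain elsewhere; in this assay compound 1 gives 44.5 ug/mL. Compound 2 `Cc1cc2ccccc2nc1-c1cn(-c2ccc(F)cc2)nn1` carries the same methyl together with a fluorinated phenyl group. For compound 2 this assay reports only a limit, > 100 ug/mL. Compound 3 `CCCCCc1cc2ccccc2nc1-c1cn(CCC(F)(F)C(F)(F)C(F)(F)C(F)(F)C(F)(F)C(F)(F)C(F)(F)C(F)(F)F)nn1` carries a pentyl chain on the core and a long fluorinated chain. For compound 3 this assay likewise reports only a limit, > 100 ug/mL. Within the data shown here, compound 2 thus sits at the limit shared by two of the three values shown (the limit of > 100 ug/mL in this assay, at which 2 of the 3 values shown sit), and no two measured compounds differ in only one place, so no single step can be sized from them. Compound 4 `CCCCc1cc2ccccc2nc1-c1cn(-c2ccc(F)cc2)nn1` is not yet measured and differs from compound 2 in one way: propyl in place of hydrogen on a saturated chain carbon bound to an aromatic carbon. Since compound 2 rests at a limit, only a move toward stronger inhibition could become visible. The step from compound 2 to compound 4 is expected to be an at least 1.2-fold lower number from compound 2 to compound 4 (0.09 log units; that floor lies within the scatter), small and possibly within scatter. Compound 4 is therefore estimated at 80 ug/mL, within a range from 30 ug/mL to 150 ug/mL.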

Compound 4, half-maximal inhibitory concentration: > 100 ug/mL
Compound 4: a limit, no number; the forecaster's own chance of this, stated with the estimate: 55%; middle value at least 1.2-fold (0.09 log units) from the limit.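

Among these compounds, compound 2 and compound 4 both rest at a limit of the assay rather than at a number, so no step between them can be read: the limit of > 100 ug/mL in this assay, at which 3 of the 4 values shown sit.
The compounds shown leave open whether propyl in place of hydrogen changes the result at all, and in which direction.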